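The compounds below may be only part of what the source reports. "The series", "measured", "known", "first", "only" and "open" are said of these compounds alone.

Measured so far:
- compound 1, `CCCCCCCCCCCCCCCCc1nc(N2CCC2)c(C)c(C)c1O`, giving 92%
- compound 2, `CCCCCCCCCCCCCCCCCCCc1nc(N(C)C)c(C)c(C)c1O`, giving 102%

Both numbers come from a functional assay on cells (Lymphocyte), read by a luciferase reporter and ATP content, with a stated time of 48 h, tested at 5 uM; a lower number here means a stronger effect, a higher number a weaker effect of the compound at the concentration tested. Compound 2 stands highest of these two, although its gap to compound 1 is within the usual scatter, so the two cannot be told apart. Compound 3, `CCCCCCCCCCCCCCCCc1nc(N(C)C)c(C)c(C)c1O`, is not yet measured; it differs from compound 2 in one place: hydrogen in place of propyl on a saturated chain carbon, ten or more bonds along the chain from an aromatic carbon. Going by the values given here, no measured pair shows this change, so no size of step is known. Since compound 2 gives 102% and compound 1 gives 92%, compound 3 is expected to move by a number 5 percentage points lower from compound 2 to compound 3 (within the scatter), a step not beyond the scatter. The estimate for compound 3 is 97%, between 85% and 108%.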

Compound 3, a percentage reported as activity, at one concentration (the size of the read-out at that concentration, not a potency): 100%
The estimate for compound 3 lay 3 percentage points below the measured number; the measured number falls inside the stated range.
By their numbers in this assay, from the lowest: compounds 1, 3 and 2 (each within the scatter of the next).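

In this assay hydrogen in place of propyl on a saturated chain carbon, ten or more bonds along the chain from an aromatic carbon, gives a step within the scatter (a number 2 percentage points lower from compound 2 to compound 3 (within the scatter)), so this much chain length makes no readable difference here. Dimethylamino in place of azetidin-1-yl on an aromatic carbon likewise stays within the scatter (a number 8 percentage points higher from compound 1 to compound 3 (within the scatter)). No measurement shown explains either step. Still open, as far as these compounds go, is whether a much shorter octyl chain, or a carboxylic acid at the chain end, would change the number. From the compounds shown here alone, whether a pyrrolidin-1-yl group in that aromatic place would do so is also open.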